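Methoxy for chloro on the cyano-bearing ring

The source may hold more compounds than are shown below. What is called first, only, known or untested is meant among the compounds shown, and "the series" means these compounds.

Three compounds sharing one core have numbers in a functional assay on CHO cells for inhibition of metabotropic glutamate receptor 5 (Rattus norvegicus), read by FLIPR and calcium flux; a lower number here means a stronger inhibitor, a higher number a weaker inhibitor. Compound 1 `COc1cccc(-c2ccc3ccc(C)nc3c2)c1` gives 860 nM, compound 2 `Cc1ccc2ccc(-c3cccc(Cl)c3)cc2n1` gives 14000 nM, and compound 3 `Cc1ccc2ccc(-c3cc(Cl)cc(C#N)c3)cc2n1` gives 1.4 nM, the lowest number of the three, far apart from the other two and well beyond the scatter in both comparisons. Compound 4 `COc1cc(C#N)cc(-c2ccc3ccc(C)nc3c2)c1` is not yet measured. It differs from compound 3 by methoxy in place of chloro on an aromatic carbon, the new group sitting meta to a cyano group. Going by the values given here, one measured step bears on this swap in the opposite sense: a 16-fold higher number from compound 1 to compound 2 (1.21 log units; beyond the scatter), where chloro replaced methoxy without a cyano group present. The reverse exchange here would therefore point toward a lower number, though compound 3 already sits so low that little room is left. The other step, a 10000-fold lower number from compound 2 to compound 3 (4.00 log units; beyond the scatter), concerns the cyano group, which both compound 3 and compound 4 keep. Compound 4 is expected in this assay at 0.8 nM, within 0.2 nM to 4 nM, a step of a 1.8-fold lower number from compound 3 to compound 4 (0.24 log units; within the scatter) that is estimated to stay near or just below compound 3.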

Compound 4, half-maximal inhibitory concentration: 2.4 nM
For compound 4 the middle estimate is 3.0-fold (0.48 log units) below the measured one; the range from low to high includes it.
By their numbers in this assay, from the lowest: compounds 3 and 4 (each within the scatter of the next); then compound 1; then compound 2.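

With the cyano group present, methoxy and chloro at this position cannot be told apart in this assay, with a 1.7-fold higher number from compound 3 to compound 4 (0.23 log units; within the scatter). The same exchange without the cyano group gave a step beyond the scatter, so the outcome of this change depends on the core: the same change on two cores in this assay, a 16-fold higher number (1.21 log units; beyond the scatter) from compound 1 to compound 2 and a 1.7-fold lower number (0.23 log units; within the scatter) from compound 4 to compound 3, 28-fold (1.45 log units) apart, beyond the scatter of two such steps. Cyano in place of hydrogen also lowers the number on the methoxy compounds, with a 360-fold lower number from compound 1 to compound 4 (2.55 log units; beyond the scatter), so the large drop is not confined to the chloro pair, although its size differs: the same change on two cores in this assay, a 10000-fold lower number (4.00 log units; beyond the scatter) from compound 2 to compound 3 and a 360-fold lower number (2.55 log units; beyond the scatter) from compound 1 to compound 4, 28-fold (1.45 log units) apart, beyond the scatter of two such steps.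

As far as these compounds go, whether this position stays as tolerant with an amine, a carboxylic acid or an ethoxy group remains open. The four compounds also do not tell why the effects of the two changes depend on each other.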